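A few compounds are considered here, and "the series" means these few. Any claim that something is new, unique, unknown or untested is made for them only; others in the source may bear on it.

Measured so far in a functional assay on MKN-45 cells (Homo sapiens) for inhibition, read by CCK-8 assay, with a stated time of 24 h (a lower number here means a stronger inhibitor, a higher number a weaker inhibitor), the values are:
- compound 1 `Cc1cccc(-n2cc(-c3ccc(/C=C4\C(=O)Nc5ccccc54)cc3)nn2)c1`: 4690 nM
- compound 2 `O=C1Nc2ccccc2/C1=C/c1ccc(-c2cn(-c3ccc(F)cc3)nn2)cc1`: 16700 nM

Only these two compounds have numbers, and the higher one belongs to compound 2, which makes it the weaker inhibitor of the pair. The next compound to consider is compound 3 `O=C1Nc2ccccc2/C1=C/c1ccc(-c2cn(-c3cccc(Cl)c3)nn2)cc1` with 3-chlorophenyl in place of 4-fluorophenyl on an aromatic nitrogen. The rest of the molecule stays the same.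

Among the measured compounds shown here, one measured step bears on this change. It is a 3.6-fold higher number from compound 1 to compound 2 (0.55 log units; beyond the scatter) and comes from 4-fluorophenyl replacing 3-methylphenyl on that same nitrogen. Because compound 1 gives 4690 nM with 3-methylphenyl and compound 3 carries a group also numbered 3, a move back towards that lower number is expected. For the measured compounds named here, the evidence is thin: a single step, and no measured compound yet holds chlorine. The expected change in this assay is therefore a modest drop in the number, estimated as a 2.4-fold lower number from compound 2 to compound 3 (0.38 log units; beyond the scatter) and uncertain in size. For compound 3 the estimated value is 7000 nM (expected range 2800 nM to 17000 nM).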

Compound 3, half-maximal inhibitory concentration: > 20000 nM
Compound 3: no number, only a limit; the forecaster's own chance of this, stated with the estimate: 5%; middle value at least 2.8-fold (0.45 log units) from the limit.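

In this assay compound 3 gives > 20000 nM, which is a limit of the assay and not a number, and the true value cannot be read from it: the limit of > 20000 nM in this assay, at which 1 of the 3 values shown sits.

Even so, chloro in place of methyl on an aromatic carbon gives an at least 4.2-fold higher number from compound 1 to compound 3 (0.62 log units; beyond the scatter), so the lower number of compound 1 does not carry over to every group with a 3 in its name, and this single change on the ring is enough to lose it. Against its other neighbour, 3-chlorophenyl in place of 4-fluorophenyl gives an at least 1.1-fold higher number from compound 2 to compound 3 (0.07 log units; that floor lies within the scatter), a floor within the scatter, so compound 2 and compound 3 cannot be put in order, and the change does not show whether the swap matters at all.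

Compound 2 and compound 3 differ in both the halogen and its place on the ring, so the effect of each remains unseparated, and 4-chlorophenyl or 3-fluorophenyl would pull them apart. Also open, on these data alone, is how an unsubstituted phenyl, or a 3-methoxyphenyl or 3-aminophenyl group, would compare with the 3-methylphenyl of compound 1.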